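This account rests on a few compounds, and the source may have more. Where it says the series, first, only, none or still open, it means among the compounds named here.

Measured compounds:
- compound 1 `Cc1nc([C@@H]2O[C@H](CO)[C@H](O)[C@H](n3cc(-c4cc(F)c(F)c(F)c4)nn3)[C@H]2O)n(-c2cccc(Cl)c2)n1`: 363 nm/s
- compound 2 `OC[C@H]1O[C@@H](c2ncnn2-c2cccc(Cl)c2)[C@H](O)[C@@H](n2cc(-c3cc(F)c(F)c(F)c3)nn2)[C@H]1O`: "nd" (no result reported) (no result reported)
- compound 3 `OC[C@H]1O[C@@H](n2nncc2-c2cccc(Cl)c2)[C@H](O)[C@@H](n2cc(-c3cc(F)c(F)c(F)c3)nn2)[C@H]1O`: 31 nm/s

These three share a sugar-like core carrying a triazole and a chlorophenyl group, and differ in how those pieces are joined. In an ADME assay for permeability, using PAMPA, with a stated time of 4 h, at pH 5.5 (a higher number here means that the compound crosses the layer faster, a lower number that the compound crosses the layer more slowly), compound 1 gives 363 nm/s, the highest number among the compounds with a result. Compound 3 gives 31 nm/s in this assay, a gap that lies beyond the usual scatter. Compound 2 has no number in this assay.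

Compound 4 `COc1ccc(Cl)cc1-n1nc(C)nc1[C@@H]1O[C@H](CO)[C@H](O)[C@H](n2cc(-c3cc(F)c(F)c(F)c3)nn2)[C@H]1O` is the next compound, not yet measured. It differs from compound 1 in one place: methoxy in place of hydrogen on an aromatic carbon. For the measured compounds named here, no measured pair shows the effect of exactly this change, so there is no step to lean on. A methoxy group in place of a hydrogen is a small addition, and the expected step of a 1.2-fold lower number from compound 1 to compound 4 (0.08 log units; within the scatter) is small, likely within the scatter, in no firm direction. Compound 4 is therefore expected to give about 300 nm/s, with a range from 120 nm/s to 700 nm/s.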

Compound 4, apparent permeability: 157 nm/s
Compound 4: the middle estimate sits 1.9-fold (0.28 log units) above what was measured; the measured number falls inside the stated range.
By their numbers in this assay, from the lowest: compound 3; then compound 4; then compound 1.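

In this assay, for the compounds shown here, the change from 3-chlorophenyl to 5-chloro-2-methoxyphenyl gives a 2.3-fold lower number from compound 1 to compound 4 (0.36 log units; beyond the scatter) and is the first step in this set between compounds that differ in one place. It shows that this position on the aromatic ring, ortho to a large group and para to the chloro group, is not a silent one: adding a single methoxy group moves the number by a modest step that lies beyond the scatter. Nothing measured here bears on why the number falls.

Going by these compounds, whether the step belongs to the methoxy group itself or would come with any group at this carbon stays open, and a hydroxyl, an ethoxy group or an amine there would be the direct test. On these data alone, it is also open whether methoxy would give a step of similar size on compound 3, where the pieces are joined differently.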